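Working notes: from compound 2 to compound 3

A few compounds are considered here, and "the series" means these few. Any claim that something is new, unique, unknown or untested is made for them only; others in the source may bear on it.

Within the data shown here, compound 2 (`COc1cc(-c2nnc(SCc3ccc(F)cc3)n2-c2ccc(N(C)C)cc2)cc(OC)c1OC`) gives 26400 nM in a functional assay on HepG2 cells (Homo sapiens) for inhibition, read by MTT assay, with a stated time of 48 h (on this read-out higher numbers stand for weaker inhibition and lower numbers for stronger inhibition), and holds the only numeric reading so far. Compound 1 (`COc1ccc(-n2c(SCC(=O)c3ccc4ccccc4c3)nnc2-c2cc(OC)c(OC)c(OC)c2)cc1`) reads > 60000 nM in this assay as a limit and not as a number. Compound 3 (`COc1cc(-c2nnc(SCC(=O)c3ccc4ccccc4c3)n2-c2ccc(N(C)C)cc2)cc(OC)c1OC`) is not yet measured. It carries (naphthalen-2-yl)carbonyl in place of 4-fluorophenyl on a saturated chain carbon bound to a sulfur. Among the measured compounds shown here, no measured step shows what such a change does in this assay, so the expectation starts from compound 2 at 26400 nM and assumes no clear direction. The expected change a 1.1-fold lower number from compound 2 to compound 3 (0.02 log units; within the scatter) stays within the usual scatter, though with wide uncertainty on both sides. For compound 3 the estimated value of 25000 nM has an expected range of 6000 nM to 60000 nM around it.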

Compound 3, half-maximal inhibitory concentration: > 60000 nM
Compound 3: a limit, no number; the forecaster's own chance of this, stated with the estimate: 25%; middle value at least 2.4-fold (0.38 log units) away from the limit.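

In this assay, among these compounds, (naphthalen-2-yl)carbonyl in place of 4-fluorophenyl on a saturated chain carbon bound to a sulfur gives the first readable step at this position: an at least 2.2-fold higher number from compound 2 to compound 3 (0.35 log units; beyond the scatter). From the compounds shown here alone, compound 3 reads as a limit, so the step gives only a minimum size, and the true size stays unknown: the limit of > 60000 nM in this assay, at which 2 of the 3 values shown sit. The step between compound 1 and compound 3, dimethylamino in place of methoxy on an aromatic carbon, cannot be read because both values are limits.

The carbonyl and the naphthalen-2-yl part enter together, so the compounds shown do not separate their contributions to the weaker reading. Also open, going by these compounds, is how a plain benzyl, a phenylcarbonyl, an amine or a carboxylic acid on this chain carbon would read.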